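A Chloro Group Added to a Compound at Its Limit

The source may hold more compounds than are shown below. What is called first, only, known or untested is meant among the compounds shown, and "the series" means these compounds.

Compound 2 `COc1ccc(-c2c(CNC(C)(C)C)c(C(=O)O)nn2-c2ccccc2)cc1` has no single number in a functional assay on MCF7 cells (Homo sapiens) for inhibition, read by sulforhodamine B assay, with a stated time of 48 h; a higher number here means a weaker inhibitor of growth, a lower number a stronger inhibitor of growth. Compound 2 stands at a limit, > 659000 nM. Compound 3 `CC(C)(C)NCc1c(C(=O)O)nn(-c2ccccc2)c1-c1ccc([N+](=O)[O-])cc1` likewise gives only a limit, > 634000 nM. Compound 1 `CCOC(=O)c1nn(-c2ccccc2)c(-c2ccc(OC)cc2)c1CNC(C)(C)C` alone gives numbers, 116000 nM; 244000 nM (2 entries). Compound 4 `COc1ccc(-c2c(CNC(C)(C)C)c(C(=O)O)nn2-c2ccc(Cl)cc2)cc1` differs from compound 2 by chloro in place of hydrogen on an aromatic carbon, phenyl to 4-chlorophenyl: chloro in place of hydrogen on an aromatic carbon. Going by the values given here, no measured step makes this change. The nearest one, a step that the two limits leave unreadable from compound 2 to compound 3, is nitro in place of methoxy on an aromatic carbon and gives no size to carry over. No shift beyond the scatter is therefore expected, and the expected step is a step that the limit leaves unreadable from compound 2 to compound 4. For compound 4 the estimate is 700000 nM, with an expected range from 300000 nM to 1500000 nM.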

Compound 4, concentration for 50% growth inhibition: 220000 nM
Compound 4: middle estimate off by 3.2-fold (0.50 log units), on the high side; the whole stated range lies above it.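

In this assay, chloro in place of hydrogen on an aromatic carbon, para to a large group, brings an at least 2.9-fold lower number from compound 2 to compound 4 (0.47 log units; beyond the scatter). This is the only readable step among the compounds shown, and it marks this place as one where adding one heavy atom moves the number beyond the scatter. Compound 4 is also the only carboxylic acid here with a single number, while the step from methoxy to nitro cannot be read.

On these data alone, compound 2 has only a limit, > 659000 nM, and the full size of the step stays open. As far as these compounds go, whether fluoro, bromo or methyl in the same place would move the number as chloro does also stays open.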